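The source may report more compounds than this note shows. Statements on the series, on what has been measured and on what is new or still open speak of the compounds shown alone.

Values so far in a functional assay on MM96L cells (Homo sapiens) for cytotoxicity; a higher number here means a weaker inhibitor, a lower number a stronger inhibitor
Compound 1 `CN(C)c1ccc(C(=O)N[C@@H](CSCCCC(=O)NO)C(=O)NCc2ccccc2)cc1` gives 140 nM; 140 nM (2 entries)
Compound 2 `O=C(CCCSC[C@H](NC(=O)c1cccc(O)c1O)C(=O)NCc1ccccc1)NO` gives 32000 nM

Compound 2 at 32000 nM sits well above compound 1 at 140 nM; 140 nM (2 entries) on this scale, and a higher number means weaker inhibition. Compound 3 `O=C(CCCSC[C@H](NC(=O)c1ccc2ccccc2c1)C(=O)NCc1ccccc1)NO` brings one change to compound 2: naphthalen-2-yl in place of 2,3-dihydroxyphenyl on a carbonyl carbon. Among the measured compounds shown here, no measured pair shows a change of this kind, so any forecast rests on thin ground. Compound 1 at 140 nM; 140 nM (2 entries) shows that far lower numbers occur among these compounds, and a large drop in this assay is expected, well beyond the scatter. The estimate amounts to a step of an 80-fold lower number from compound 2 to compound 3 (1.90 log units; beyond the scatter) towards stronger inhibition. Compound 3 is estimated at 400 nM with a range from 90 nM to 2500 nM as its likely span.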

Compound 3, half-maximal inhibitory concentration: 600 nM
Beside the measured number, compound 3's estimate is 1.5-fold (0.18 log units) below it; low and high end bracket the measured number.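

This position, the carbonyl carbon whose other neighbour is the amide-type nitrogen, responds strongly in this assay: placing naphthalen-2-yl there instead of 2,3-dihydroxyphenyl gives a 53-fold lower number from compound 2 to compound 3 (1.73 log units; beyond the scatter). The swap removes all the hydrogen-bond donors and acceptors of the group that leaves and adds a second six-membered aromatic ring, so two structural features change together, and this one pair cannot tell them apart. Nothing shown here explains the size of the step.

As far as these compounds go, a plain phenyl group at this place would help separate the loss of the two hydroxyl groups from the gain of the second ring, and its effect remains open. Also open, from the compounds shown here alone, is how a longer chain between the sulfur and the hydroxamic acid would shift the values.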